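The compounds below may be only part of what the source reports. "The series", "measured", "known", "first", "only" and "open" are said of these compounds alone.

Measured so far in a functional assay on MCF7 cells (Homo sapiens) for cytotoxicity, read by MTT assay, with a stated time of 48 h; on this read-out lower numbers stand for an effect already at smaller amounts and higher numbers for an effect only at larger amounts of compound:
- compound 1 `Cc1c(O)c(=O)ccn1CC(=O)N/N=C1\C(=O)N(CC(=O)Nc2ccc(Cl)cc2)c2ccccc21`; compound 1 gives 31400 nM
- compound 2 `Cc1ccc(NC(=O)CN2C(=O)/C(=N\NC(=O)Cn3ccc(=O)c(O)c3C)c3ccccc32)cc1`; compound 2 gives 52200 nM
- compound 3 `Cc1cccc(NC(=O)CN2C(=O)/C(=N\NC(=O)Cn3ccc(=O)c(O)c3C)c3ccccc32)c1C`; compound 3 gives 51900 nM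

On these numbers compound 3 gives the second highest value, yet its steps to the other two, a 1.0-fold lower number from compound 2 to compound 3 (0.00 log units; within the scatter) and a 1.7-fold higher number from compound 1 to compound 3 (0.22 log units; within the scatter), are within the scatter, so the three compounds are not separated. Compound 4 `Cc1c(O)c(=O)ccn1CC(=O)N/N=C1\C(=O)N(CC(=O)Nc2ccc(Cl)cc2Cl)c2ccccc21` carries the change (2,4-dichlorophenyl in place of 2,3-dimethylphenyl on an amide-type nitrogen). For the measured compounds named here, the steps that bear on it are a 1.7-fold higher number from compound 1 to compound 3 (0.22 log units; within the scatter) and a 1.7-fold higher number from compound 1 to compound 2 (0.22 log units; within the scatter), both within the scatter; a second chloro on the phenyl has no counterpart among the measured compounds. Compound 4 is therefore expected to give 30000 nM (range 12000 nM to 75000 nM), a step of a 1.7-fold lower number from compound 3 to compound 4 (0.24 log units; within the scatter) expected to stay within the scatter.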

Compound 4, half-maximal effective concentration: 43200 nM
For compound 4 the middle estimate is 1.4-fold (0.16 log units) below the measured one; the measured number falls inside the stated range.
By their numbers in this assay, from the lowest: compounds 1, 4, 3 and 2 (each within the scatter of the next).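

In this assay, for the compounds shown here, a second chloro on the phenyl, a change with no earlier counterpart, stays within the scatter (a 1.4-fold higher number from compound 1 to compound 4 (0.14 log units; within the scatter)). The 2,4-dichlorophenyl group on the amide-type nitrogen is likewise not separated from the methyl-bearing groups (a 1.2-fold lower number from compound 3 to compound 4 (0.08 log units; within the scatter) and a 1.2-fold lower number from compound 2 to compound 4 (0.08 log units; within the scatter)), so all four compounds remain unresolved at this position. No data are at hand to explain this flat picture. The compounds shown carry only chloro and methyl on the phenyl. On these data alone, whether an amine or a carboxylic acid on that ring, or a longer chain on the amide-type nitrogen, would move the number beyond the scatter stays open.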